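The source may hold more compounds than are shown below. What is called first, only, known or untested is meant among the compounds shown, and "the series" means these compounds.

Compound 1 `CCCn1c(NC(=O)c2cccnn2)nc2cc(C(N)=O)cc(OC)c21` in an assay for activation of interferon regulatory factor 3 (Homo sapiens), read by a luciferase reporter, with a stated time of 20 h (a higher number here means that more compound is needed for the effect, a lower number that less compound is needed), gives > 100000 nM, which is a limit of the assay and not a number.
Compound 2 `CCCn1c(NC(=O)c2cncn2C)nc2cc(C(N)=O)cc(OC)c21` in this assay gives > 100000 nM, likewise a limit.
Compound 3 `CCCn1c(NC(=O)c2cc3ccccc3n2C)nc2cc(C(N)=O)cc(OC)c21` in this assay gives > 100000 nM, again a limit.

Compound 3 thus stands at the limit, as do the two other values shown (the limit of > 100000 nM in this assay, at which 3 of the 3 values shown sit). The steps among the measured compounds, a step that the two limits leave unreadable from compound 1 to compound 2, a step that the two limits leave unreadable from compound 1 to compound 3 and a step that the two limits leave unreadable from compound 2 to compound 3, cannot be read, since both ends of each sit at the limit; exchanging the heteroaryl group on the carbonyl carbon across these three compounds did not bring any of them to a readable value.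

Compound 4 `COc1cc(C(N)=O)cc2nc(NC(=O)c3cc4ccccc4n3C)n(CCCNC(=O)OCc3ccccc3)c12` differs from compound 3 by (benzyloxycarbonyl)amino in place of hydrogen on a saturated chain carbon, three bonds along the chain from an aromatic nitrogen. Going by the values given here, none of the measured steps touches this chain position; all concern the group on the carbonyl carbon, and none is readable in size or direction. There is therefore no measured basis for a shift, and the step from compound 3 to compound 4 is expected to be a number no higher from compound 3 to compound 4 (the limit leaves the size open). Compound 4 is expected to give about 100000 nM, in the range 20000 nM to 300000 nM, with the outcome most likely reported again only as a limit of the assay.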

Compound 4, half-maximal effective concentration: > 100000 nM
Compound 4: no number, only a limit; the forecaster's own chance of this, stated with the estimate: 80%; the middle value sits exactly at the limit.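

In this assay compound 4 gives > 100000 nM, a limit of the assay and not a number. No step can be read between compound 3 and compound 4, since both sit at the same limit: the limit of > 100000 nM in this assay, at which 4 of the 4 values shown sit. The compounds shown leave open whether either the group on the carbonyl carbon or the (benzyloxycarbonyl)amino group on the chain changes the value at all.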